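The compounds below may be only part of what the source reports. "The series", "measured", "known", "first", "only" and "open" are said of these compounds alone.

Compound 3 `Cc1c(C(=O)Nc2c(F)cc(-c3cccc(F)c3)cc2F)nc2ccc(F)cc2c1C(=O)O` stands with a read-out of -0.35% in a functional assay on Hep 3B2 cells (Homo sapiens) for antiproliferative activity, read by MTT assay, with a stated time of 24 h, tested at 0.01 ug/mL (on this read-out lower numbers stand for a weaker effect and higher numbers for a stronger effect at the one concentration tested), second highest of the three numbers available. Its nearest neighbour is compound 1 `CCOc1ccc2nc(C(=O)Nc3c(F)cc(-c4cccc(F)c4)cc3F)c(C)c(O)c2c1`, which gives -0.5%, and the furthest is compound 2 `Cc1ccc2nc(C(=O)Nc3c(F)cc(-c4cccc(F)c4)cc3F)c(C)c(C(=O)O)c2c1`, which gives 0.36%; all three lie within the scatter of one another, so none can be called stronger or weaker.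

Compound 4 `CCOc1ccc2nc(C(=O)Nc3c(F)cc(-c4cccc(F)c4)cc3F)c(C)c(C(=O)O)c2c1` arises from compound 3 by a single change: ethoxy in place of fluoro on an aromatic carbon. Among the compounds with values here, only one measured step touches the same aromatic carbon, the change of fluoro in place of methyl, where a number 0.7 percentage points lower from compound 2 to compound 3 (within the scatter). Compound 1 also carries the ethoxy group, though it differs from compound 4 elsewhere, and its value likewise sits near zero. Within the data shown here, since every number so far stays within the scatter, no step beyond it is expected here; the expected step of a number 0.4 percentage points higher from compound 3 to compound 4 (within the scatter) is essentially nil. Compound 4 is therefore estimated at 0%, within a range from -8% to 8%.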

Compound 4, a percentage reported as inhibition, at one concentration (the size of the read-out at that concentration, not a potency): -0.12%
For compound 4 the middle estimate is 0.1 percentage points above the measured one; low and high end bracket the measured number.
By their numbers in this assay, from the lowest: compounds 1, 3, 4 and 2 (each within the scatter of the next).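

In this assay, ethoxy in place of fluoro on this aromatic carbon gives a number 0.2 percentage points higher from compound 3 to compound 4 (within the scatter), and ethoxy in place of methyl there gives a number 0.5 percentage points lower from compound 2 to compound 4 (within the scatter), so fluoro, methyl and ethoxy at this position cannot be told apart on this read-out. With ethoxy held in place, carboxy in place of hydroxy on another aromatic carbon gives a number 0.4 percentage points higher from compound 1 to compound 4 (within the scatter), so this second change cannot be told apart from no change either. No other data are available to explain these readings.

Going by these compounds, whether an amine or a longer chain such as butoxy at the ethoxy position would give a step beyond the scatter remains open. Also open, on these data alone, is whether these compounds would separate at any concentration other than the single one used here.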